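Chain-terminal triazole in place of alkyl on the aminopyrimidine series

The source may report more compounds than this note shows. Statements on the series, on what has been measured and on what is new or still open speak of the compounds shown alone.

Measured so far in an assay on HEK293 cells for agonist activity at Toll-like receptor 8 (Homo sapiens), read by spectrophotometry; a higher number here means that more compound is needed for the effect, a lower number that less compound is needed:
compound 1 `CCCCNc1nc(N)nc(C)c1CC` — 1660 nM
compound 2 `CCCCNc1nc(N)nc(C)c1CCC(C)(C)O` — 3140 nM
compound 3 `CCCCCc1c(C)nc(N)nc1NCCCC` — 1220 nM

Compound 3 gives the lowest number of the three, but its gap to compound 1 lies within the scatter: a 1.4-fold lower number from compound 1 to compound 3 (0.13 log units; within the scatter). Only its gap to compound 2 is beyond it: a 2.6-fold lower number from compound 2 to compound 3 (0.41 log units; beyond the scatter). Compound 4 `CCCCNc1nc(N)nc(C)c1CCCn1cncn1` is still unmeasured; it carries 1H-1,2,4-triazol-1-yl in place of ethyl on a saturated chain carbon, three bonds along the chain from an aromatic carbon. The nearest precedents are a 1.9-fold higher number from compound 1 to compound 2 (0.28 log units; within the scatter), where a polar group replaced hydrogen on the chain, and the step from compound 2 to compound 3 above, where alkyl replaced that polar group. Both point the same way, so a modest rise in the number is expected for compound 4: a 2.0-fold higher number from compound 3 to compound 4 (0.31 log units; beyond the scatter). The estimate for compound 4 in this assay is 2500 nM, with a range of 1000 nM to 6500 nM.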

Compound 4, half-maximal effective concentration: 1050 nM
Beside the measured number, compound 4's estimate is 2.4-fold (0.38 log units) above it, and the stated range covers the measured number.
By their numbers in this assay, from the lowest: compounds 4, 3, 1 and 2 (each within the scatter of the next, the first and the last beyond it).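

In this assay, 1H-1,2,4-triazol-1-yl, with its five-membered aromatic ring, is accepted in place of ethyl on the saturated chain without leaving the scatter (a 1.2-fold lower number from compound 3 to compound 4 (0.07 log units; within the scatter)), and the same holds against the shorter chain (a 1.6-fold lower number from compound 1 to compound 4 (0.20 log units; within the scatter)). Heteroatoms on this chain therefore do not go with a higher number as such, with the 1-hydroxy-1-methylethyl chain as the exception (a 3.0-fold lower number from compound 2 to compound 4 (0.48 log units; beyond the scatter)). No measurement in hand accounts for this difference between the two groups.

As far as these compounds go, whether an amine, a carboxylic acid or another azole would behave like the triazole remains open. So does the effect of a longer chain carrying the triazole.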